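Methoxyphenyl sulfonamide: cytotoxicity expected near the assay ceiling

The source may hold more compounds than are shown below. What is called first, only, known or untested is meant among the compounds shown, and "the series" means these compounds.

Compound 1 `Cc1ccccc1S(=O)(=O)Nc1ccc2oc(-c3ccccc3)nc2c1`: 57000 nM
Compound 2 `O=S(=O)(Nc1ccc(-c2nc3ccccc3o2)cc1)c1cccc(O)c1`: > 100000 nM
Compound 3 `O=S(=O)(Nc1ccc(-c2nc3ccccc3o2)cc1)c1ccccc1O`: > 100000 nM

For the measured compounds named here, in an ADME assay on HEK293 cells (Homo sapiens) for cytotoxicity, read by resazurin assay, with a stated time of 48 h (a lower number here means that less compound is tolerated, a higher number that more compound is tolerated), compound 1 gives 57000 nM, the only plain number among the three measured compounds. For compound 2 the value > 100000 nM is a limit of the assay, not a number. For compound 3 the value > 100000 nM is likewise a limit. The step that the two limits leave unreadable from compound 2 to compound 3 is therefore unreadable, and it concerns a hydroxyphenyl change that does not overlap with the change considered here.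

Compound 4 `COc1ccc(S(=O)(=O)Nc2ccc3oc(-c4ccccc4)nc3c2)cc1` has not yet been measured. It differs from compound 1 as follows: 4-methoxyphenyl in place of 2-methylphenyl on a sulfonyl sulfur. Going by the values given here, no measured step bears on this change, so no direction can be read from the data; the one signal is the limit of > 100000 nM in this assay, at which 2 of the 3 values shown sit, which shows that most compounds of this shared core are not read as a number in this assay. The step from compound 1 to compound 4 is therefore expected to be a 1.3-fold higher number from compound 1 to compound 4 (0.12 log units; within the scatter), small or absent beyond the scatter, with a fair chance that only a limit is reported. Compound 4 is estimated at 75000 nM, between 30000 nM and 160000 nM.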

Compound 4, half-maximal cytotoxic concentration: 91000 nM
For compound 4 the middle estimate is 1.2-fold (0.08 log units) below the measured one; the measured number falls inside the stated range.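

In this assay, for the compounds shown here, the change to 4-methoxyphenyl in place of 2-methylphenyl on a sulfonyl sulfur gives a 1.6-fold higher number from compound 1 to compound 4 (0.20 log units; within the scatter), the first step whose size can be read. The two compounds therefore cannot be told apart, even though the entering group brings one hydrogen-bond acceptor and the leaving group has none. Compound 4 is reported as a plain number, as compound 1 is, whereas the remaining values are limits and not numbers: the limit of > 100000 nM in this assay, at which 2 of the 4 values shown sit.

As far as these compounds go, the step between the two hydroxyphenyl compounds cannot be read, so the effect of moving that hydroxyl group stays unknown. From the compounds shown here alone, it also remains open whether an amine or a carboxylic acid on the phenyl ring at the sulfonyl sulfur would move the number beyond the scatter from compound 1.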